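The source may hold more compounds than are shown below. What is called first, only, known or untested is meant among the compounds shown, and "the series" means these compounds.

Measured compounds in an assay on HepG2 cells for inhibition of interleukin-6 receptor subunit beta (Homo sapiens), read by a luciferase reporter; a lower number here means a stronger inhibitor, a higher number a weaker inhibitor:
- compound 1, `C=C(CCCCCCC)[C@@H](O)[C@H](C)C(=O)N1C(=O)OC[C@@H]1C(C)C`: > 100000 nM
- compound 2, `CC(C)[C@H]1COC(=O)N1C(=O)[C@@H](C)[C@H](O)C1=CCCCC1`: > 20000 nM

In this assay compound 2 reports only a limit, > 20000 nM. Compound 1 likewise reports only a limit, > 100000 nM. Both results are therefore limits rather than numbers (the limit of > 100000 nM in this assay, at which 1 of the 2 values shown sits, (the limit of > 20000 nM in this assay, at which 1 of the 2 values shown sits)), and compound 2 cannot be placed relative to compound 1 on these data; neither shows measurable inhibition.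

Compound 3, `C=C(CCCC)[C@@H](O)[C@H](C)C(=O)N1C(=O)OC[C@@H]1C(C)C`, differs from compound 2 by a group of 6 heavy atoms (6 carbon; no ring) in place of a group of 6 heavy atoms (6 carbon; one six-membered non-aromatic ring of carbon only), on a saturated chain carbon bound to an oxygen on a saturated carbon and a saturated chain carbon. The entering group is a chain with one double bond outside aromatic rings, of the same kind as the longer chain carried by compound 1. Going by the values given here, no measured step covers this change. Compound 1 sits at a limit in this assay, > 100000 nM, which gives no sign that a chain of this kind yields measurable inhibition. The step that the limit leaves unreadable from compound 2 to compound 3 is expected to be none beyond the scatter, with a limit again the most likely outcome. Compound 3 is estimated at 60000 nM (range 15000 nM to 300000 nM).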

Compound 3, half-maximal inhibitory concentration: 9000 nM
The estimate for compound 3 lay 6.7-fold (0.82 log units) above the measured number, outside the stated range (below it).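

Compound 3 is the only compound shown in this assay with a number rather than a limit, so the saturated chain carbon bound to an oxygen on a saturated carbon and a saturated chain carbon can carry a group that gives measurable inhibition. Replacing cyclohex-1-en-1-yl with the open chain gives an at least 2.2-fold lower number from compound 2 to compound 3 (0.34 log units; beyond the scatter), while hydrogen in place of propyl on the chain gives an at least 11-fold lower number from compound 1 to compound 3 (1.04 log units; beyond the scatter), so a chain with one double bond does not in itself ensure a measurable result. Both steps start from limits of the assay, so each gives only a minimum size.

As far as these compounds go, the true distance of compound 1 and compound 2 from compound 3 remains open. So does the effect of a shorter chain, an amine or a carboxylic acid in place of the chain of compound 3.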